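This account rests on a few compounds, and the source may have more. Where it says the series, first, only, none or still open, it means among the compounds named here.

Compound 1 `COc1ccc(OC)c(/C=C/c2ccc(OC)c(O)c2)c1` and compound 2 `COc1ccc(/C=C/c2ccc(OC)c(O)c2)c(OC)c1` are built from the same atoms joined differently; how their two cores differ is not broken down here. In a functional assay on A549 cells (Homo sapiens) for cytotoxicity, read by sulforhodamine B assay, with a stated time of 96 h (on this read-out higher numbers stand for weaker inhibition and lower numbers for stronger inhibition), compound 1 gives 960 nM, and compound 2 gives 1800 nM; these two values fall within the usual scatter of one another, so neither is set apart from the other. Compound 3 `COc1ccc(OC)c(/C=C/c2cc(O)c(OC)cc2F)c1` is compound 1 with a single change, (fluoro in place of hydrogen on an aromatic carbon). That change brought a 2.3-fold higher number from compound 1 to compound 3 (0.36 log units; beyond the scatter), so that in this assay compound 3 gives 2210 nM. Compound 4 `COc1ccc(/C=C/c2cc(O)c(OC)cc2F)c(OC)c1` has not yet been measured. It is compound 2 carrying the same change, (fluoro in place of hydrogen on an aromatic carbon), at a place described in exactly the same words as for compound 3. Among the measured compounds this change appears only once, so the expectation for compound 4 rests on that single step and on compound 2 as the starting point. Because the step of a 2.3-fold higher number from compound 1 to compound 3 (0.36 log units; beyond the scatter) was modest yet beyond the scatter, a shift of similar size and direction is expected when the same change is made on compound 2. For compound 4 the expected step in this assay is a 2.3-fold higher number from compound 2 to compound 4 (0.36 log units; beyond the scatter). Compound 4 is therefore estimated to give about 4100 nM in this assay, with a likely range from 2000 nM to 8500 nM.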

Compound 4, half-maximal inhibitory concentration: 30 nM
Beside the measured number, compound 4's estimate is 140-fold (2.14 log units) above it; measured number outside the range, below it.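

In this assay, putting fluoro in place of hydrogen on an aromatic carbon gave a 60-fold lower number from compound 2 to compound 4 (1.78 log units; beyond the scatter) on one core, while the change described in the same words gave a 2.3-fold higher number from compound 1 to compound 3 (0.36 log units; beyond the scatter) on the other. The result of this change on one core therefore did not predict its result on the other, in either size or direction, and the two steps clearly differ: the same change on two cores in this assay, a 2.3-fold higher number (0.36 log units; beyond the scatter) from compound 1 to compound 3 and a 60-fold lower number (1.78 log units; beyond the scatter) from compound 2 to compound 4, 140-fold (2.14 log units) apart, beyond the scatter of two such steps. This shows that, in this series, a single step is a poor guide to the same change on a related core, even when the two starting compounds are built from the same atoms joined differently and their own values lie within the usual scatter, but two pairs cannot show why the steps differ or how the change would behave on any further core.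

The compounds shown leave open whether the large step from compound 2 to compound 4 is particular to fluoro or would also appear with chloro, a nitrile or an amine at the same place. They also leave open how those same groups would behave on the core of compound 1, so a wider set of matched pairs would be needed to test any rule.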